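Cytotoxicity limits across four related compounds

The compounds below may be only part of what the source reports. "The series", "measured", "known", "first", "only" and "open" are said of these compounds alone.

Measured so far:
- compound 1 `CC(C)N(Cc1cccc(OCCCCCC(=O)O)c1)C(=O)c1ccc(-c2cccc(Br)c2)cc1`: > 26000 nM (a limit of the assay, not a number)
- compound 2 `CC(C)N(Cc1cccc(OCCCCCC(=O)O)c1)C(=O)c1ccc(-c2ccc(Cl)c(Cl)c2)cc1`: > 26000 nM (a limit of the assay, not a number)
- compound 3 `CCOC(=O)CCCCCOc1cccc(CN(C(=O)c2ccc(-c3cccc(Br)c3)cc2)C(C)C)c1`: > 26000 nM (a limit of the assay, not a number)

All three values were obtained in an ADME assay on HEK293 cells (Homo sapiens) for cytotoxicity, read by CellTiter-Glo and resazurin assay, with a stated time of 72 h; on this read-out higher numbers stand for an effect only at larger amounts of compound and lower numbers for an effect already at smaller amounts. For the measured compounds named here, each of them is a limit, so no compound has a number in this assay and none of the three can be placed in order against the others.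

Two steps connect the measured compounds. From compound 1 to compound 2 the change is 3,4-dichlorophenyl in place of 3-bromophenyl on an aromatic carbon, and the step that the two limits leave unreadable from compound 1 to compound 2 cannot be read because of the limit of > 26000 nM in this assay, at which 3 of the 3 values shown sit. From compound 1 to compound 3 the change is ethyl in place of hydrogen on an oxygen next to a carbonyl group, which is also how the core of compound 3 differs from the core of compound 1; the step that the two limits leave unreadable from compound 1 to compound 3 is likewise unreadable because of the limit of > 26000 nM in this assay, at which 3 of the 3 values shown sit.

Compound 4 `CCOC(=O)CCCCCOc1cccc(CN(C(=O)c2ccc(-c3ccc(Cl)c(Cl)c3)cc2)C(C)C)c1` is not yet measured in this assay. It differs from compound 3 by 3,4-dichlorophenyl in place of 3-bromophenyl on an aromatic carbon. The place of this change is word for word the same as the place of the change from compound 1 to compound 2, so it is the same change, made here on the core of compound 3.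

Compound 4 is expected to remain at the limit as well, an expected step that the limit leaves unreadable from compound 3 to compound 4, resting on the fact that compound 1 and compound 2 both sit at the limit of > 26000 nM in this assay, at which 3 of the 3 values shown sit, and that a step that the two limits leave unreadable from compound 1 to compound 2 showed nothing readable. Compound 4 is therefore estimated at 30000 nM, within 15000 nM to 60000 nM.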

Compound 4, half-maximal effective concentration: > 26000 nM
Compound 4 ended at the assay's limit (the forecaster's own chance of this, stated with the estimate: 85%); the middle value is on the limit's open side.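

For the compounds shown here, compound 4 joins compound 1, compound 2 and compound 3 as a limit in this assay and no step from compound 3 or compound 2 to compound 4 can be read, because no compound has a number: the limit of > 26000 nM in this assay, at which 4 of the 4 values shown sit.

The compounds shown leave open at what concentration, if any, each of the four would reach a half-maximal effect, and whether either change would shift it.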